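Two anilinopyrimidine amines and a third awaiting its growth value

The source may hold more compounds than are shown below. What is called first, only, known or untested is meant among the compounds shown, and "the series" means these compounds.

Measured so far:
compound 1 `CCN1CCN(c2ccc(Nc3ncc(Cl)c(Nc4ccccc4C)n3)nc2)CC1` — > 100000 nM
compound 2 `CN1CCN(c2ccc(Nc3ncc(Cl)c(NCc4ccccc4)n3)nc2)CC1` — 17300 nM

In a functional assay on MCF7 cells (Homo sapiens) for inhibition, read by CCK-8 assay, with a stated time of 48 h (on this read-out lower numbers stand for stronger inhibition of growth and higher numbers for weaker inhibition of growth), compound 1 gives > 100000 nM, which is a limit of the assay and not a number. In this assay, within the data shown here, compound 2 gives 17300 nM; this is the only number in the set. Among the measured compounds shown here, compound 1 and compound 2 differ in more than one place, so no single step joins them; their two values show only that compound 2 gives a number where compound 1 reaches the limit (the limit of > 100000 nM in this assay, at which 1 of the 2 values shown sits).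

Compound 3 `CC(C)c1cccc(Nc2nc(Nc3ccc(N4CCN(C)CC4)cn3)ncc2Cl)c1` is not yet measured. It differs from compound 2 by 3-isopropylphenyl in place of benzyl on a nitrogen on an aromatic ring. For the measured compounds named here, with no step between measured compounds to lean on, the size and direction of this change can only be guessed. The expectation is a step from compound 2 of a 2.0-fold higher number from compound 2 to compound 3 (0.31 log units; beyond the scatter), a weakening beyond the scatter, with a real chance that only a limit is returned. For compound 3 in this assay the estimate is 35000 nM, ranging from 5000 nM to 100000 nM.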

Compound 3, concentration for 50% growth inhibition: 8640 nM
Beside the measured number, compound 3's estimate is 4.1-fold (0.61 log units) above it; the measured number falls inside the stated range.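

The series now has one readable step at this position in this assay: a 2.0-fold lower number from compound 2 to compound 3 (0.30 log units; within the scatter), for 3-isopropylphenyl in place of benzyl on a nitrogen on an aromatic ring. Read one bond further out, the change from benzylamino to (3-isopropylphenyl)amino therefore gives no basis for ranking compound 2 and compound 3, and this position takes either group without a change that can be told from the scatter. Compound 3 returns a number and not a limit, so among the compounds shown the limit stays with compound 1 alone: the limit of > 100000 nM in this assay, at which 1 of the 3 values shown sits.

Compound 1 differs from compound 3 in more than one place, so the data do not assign the gap between a limit and a number to either the substituent on the phenyl ring or the group on the piperazine-bearing end of the molecule. As far as these compounds go, how a longer chain such as phenethyl, or a phenyl ring carrying a carboxylic acid or an amine, would read at this nitrogen in this assay remains open.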